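A few compounds are considered here, and "the series" means these few. Any claim that something is new, unique, unknown or untested is made for them only; others in the source may bear on it.

Measured so far:
compound 1 `N[C@@H](CC1CCCCC1)CN(C(=O)[C@@H]1C[C@H]1c1ccccc1)c1ccc(-c2ccccc2)cc1` — in a functional assay for agonist activity at G protein-coupled receptor 88 (Homo sapiens), read by HTRF and cAMP accumulation (a lower number here means that less compound is needed, a higher number that more compound is needed for the effect), compound 1 gives 1.7 nM
compound 2 `N[C@H](CN(C(=O)[C@@H]1C[C@H]1c1ccccc1)c1ccc(-c2ccccc2)cc1)C1CCCCC1` — compound 2 gives 0.66 nM
compound 3 `CC(C)C[C@H](N)CCN(C(=O)[C@@H]1C[C@H]1c1ccccc1)c1ccc(-c2ccccc2)cc1` — compound 3 gives 3 nM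

Among these three, compound 3 carries the highest number: compound 1 sits closest, with the difference between them within the scatter, and compound 2 furthest, as shown by a 4.5-fold higher number from compound 2 to compound 3 (0.66 log units; beyond the scatter).

Compound 4 `O=C([C@@H]1C[C@H]1c1ccccc1)N(CCNCC1CCCC1)c1ccc(-c2ccccc2)cc1` is the next compound. It differs from compound 3 in one place: (cyclopentylmethyl)amino in place of 1-amino-3-methylbutyl on a saturated chain carbon, two bonds along the chain from an amide-type nitrogen. Within the data shown here, none of the measured steps makes exactly this change. The nearest are a 2.6-fold lower number from compound 1 to compound 2 (0.41 log units; beyond the scatter), where a ring replaces a ring bearing one more chain carbon, and a 1.8-fold higher number from compound 1 to compound 3 (0.25 log units; within the scatter), where the amine-bearing part is reshaped. Both are small to modest, so a modest step in this assay is the most that can be expected here, and with the amine-bearing part rebuilt more thoroughly than in any measured step, the direction is uncertain; a somewhat higher number is taken as the more likely outcome.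

Compound 4 is therefore expected to give about 8 nM, within a range of 2 nM to 40 nM, which amounts to an estimated step of a 2.7-fold higher number from compound 3 to compound 4 (0.43 log units; beyond the scatter).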

Compound 4, half-maximal effective concentration: 2.5 nM
Compound 4: middle estimate off by 3.2-fold (0.51 log units), on the high side, within the range that was stated.
By their numbers in this assay, from the lowest: compound 2; then compounds 1, 4 and 3 (each within the scatter of the next).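

In this assay, this position tolerates (cyclopentylmethyl)amino in place of 1-amino-3-methylbutyl (a 1.2-fold lower number from compound 3 to compound 4 (0.08 log units; within the scatter)), so swapping an open chain with a defined stereocentre for a five-membered carbon ring without a stereocentre leaves the number within the scatter. Compound 4 also cannot be separated from the cyclohexylmethyl-bearing compound 1 (a 1.5-fold higher number from compound 1 to compound 4 (0.17 log units; within the scatter)), and only compound 2 stands clearly apart (a 3.8-fold higher number from compound 2 to compound 4 (0.58 log units; beyond the scatter)). Nothing measured here explains why these different groups read alike.

It remains open whether the amine is needed at all, since none of these compounds has a hydroxyl or an ether oxygen at this place. As far as these compounds go, it is also open whether a (cyclohexylmethyl)amino group would read like the (cyclopentylmethyl)amino group.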